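The compounds below may be only part of what the source reports. "The series", "measured", "known", "first", "only" and "open" are said of these compounds alone.

The compounds share one core, shown for compound 1 as `CCOC(=O)Nc1ccc(S(=O)(=O)N2C(=O)N[C@@H](c3ccccc3)C2C)cc1Cl`. In a functional assay on HCT-116 cells (Homo sapiens) for cytotoxicity, read by MTT assay (on this read-out higher numbers stand for weaker inhibition and lower numbers for stronger inhibition), compound 1 gives 5500 nM. Compound 3, `CCOC(=O)Nc1ccc(S(=O)(=O)N2C(=O)N[C@@H](c3ccccc3)C2C)cc1C`, gives 5500 nM; the step of no change at the digits printed from compound 1 to compound 3 (within the scatter) shows that exchanging methyl for chloro on the aromatic carbon leaves the read-out where it was, and these two compounds together stand at the highest numbers of the three. Among the compounds with values here, compound 2, `CCOC(=O)Nc1ccc(S(=O)(=O)N2C[C@H](c3ccccc3)NC2=O)cc1Cl`, gives 200 nM, and the step of a 28-fold lower number from compound 1 to compound 2 (1.44 log units; beyond the scatter), the removal of the methyl from the saturated ring carbon, is the only large step among the measured pairs.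

Compound 4, `CC1[C@H](c2ccccc2)NC(=O)N1S(=O)(=O)c1ccc(NC(=O)c2ccc([N+](=O)[O-])cc2)c(Cl)c1`, differs from compound 1 in one place: 4-nitrophenyl in place of ethoxy on a carbonyl carbon. Neither measured step touches this carbonyl carbon: the step of a 28-fold lower number from compound 1 to compound 2 (1.44 log units; beyond the scatter) concerns the saturated ring and the step of no change at the digits printed from compound 1 to compound 3 (within the scatter) concerns the aromatic carbon, so no measurement shows how the read-out responds to a change at this carbon. With nothing to point either way, the expected step of a 1.1-fold lower number from compound 1 to compound 4 (0.04 log units; within the scatter) is none beyond the scatter, but the range must be wide. Compound 4 is therefore estimated at 5000 nM, between 1200 nM and 20000 nM.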

Compound 4, half-maximal inhibitory concentration: > 10000 nM
Compound 4: no number, only a limit (the forecaster's own chance of this, stated with the estimate: 10%); middle value at least 2.0-fold (0.30 log units) from the limit.
By their numbers in this assay, from the lowest: compound 2; then compounds 1 and 3 (each within the scatter of the next). At a limit, above all of these: compound 4.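

Within the data shown here, compounds 2 and 3 changed the saturated ring carbon and the aromatic carbon, so compound 4 is the first of the compounds to test the carbonyl carbon whose other neighbour is an amide-type nitrogen. The reading for compound 4 in this assay is a limit of the assay and not a number: the limit of > 10000 nM in this assay, at which 1 of the 4 values shown sits. Exchanging ethoxy for the larger 4-nitrophenyl, which brings an aromatic ring to this carbon, gives an at least 1.8-fold higher number from compound 1 to compound 4 (0.25 log units; that floor lies within the scatter), so this change brings no gain on this read-out, but how far the number rises, and whether the rise goes beyond the scatter, cannot be read.

Only these two groups on this carbonyl carbon are shown, so it remains open how a methyl, an unsubstituted phenyl or an amine would read there, and whether the ring or its nitro group matters more for the result. Among these compounds, also open is how the same exchange would read on compound 2, which has the lowest number of the series, as this change is seen only on the core of compound 1.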